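A few compounds are considered here, and "the series" means these few. Any claim that something is new, unique, unknown or untested is made for them only; others in the source may bear on it.

Measured compounds in an in vitro functional assay on cells for antagonist activity at B1 bradykinin receptor (Homo sapiens), read by luminescence and calcium flux, with a stated time of 2 h; on this read-out higher numbers stand for weaker inhibition and lower numbers for stronger inhibition:

- compound 1 `Cc1ccc(S(=O)(=O)N2C=CNC(=O)[C@H]2CC(=O)N[C@H]2CCN(C)CC2(C)C)cc1` gives 0.42 nM
- compound 2 `CCCN1CC[C@H](NC(=O)C[C@@H]2C(=O)NC=CN2S(=O)(=O)c2ccc(C)cc2)C(C)(C)C1` gives 0.51 nM
- compound 3 `Cc1ccc(S(=O)(=O)N2C=CNC(=O)[C@H]2CC(=O)N[C@H]2CCN(CC(C)(C)C)CC2(C)C)cc1` gives 1.38 nM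

Compound 3 stands at the highest of the three numbers in this assay, with compound 2 nearest and compound 1 furthest from it. The steps that lead there are a 3.3-fold higher number from compound 1 to compound 3 (0.52 log units; beyond the scatter) and a 2.7-fold higher number from compound 2 to compound 3 (0.43 log units; beyond the scatter), both modest and beyond the scatter, while a 1.2-fold higher number from compound 1 to compound 2 (0.08 log units; within the scatter) stays within it. Growing the chain on the saturated carbon bound to the ring amine nitrogen from hydrogen to ethyl thus changes nothing that can be read, whereas going on to tert-butyl costs a modest amount.

Compound 4 `Cc1ccc(S(=O)(=O)N2C=CNC(=O)[C@H]2CC(=O)N[C@H]2CCN(Cc3ccccc3)CC2(C)C)cc1` is the next point on that same carbon: phenyl in place of tert-butyl on a saturated chain carbon bound to an amine nitrogen in a ring. Among the measured compounds shown here, no measured step covers an aromatic group at this place, so the bearing of the three steps is indirect. They show that the tert-butyl in compound 3 carries a modest penalty relative to smaller groups, and phenyl is a different kind of group of similar size. The expectation is therefore a step of a 1.4-fold lower number from compound 3 to compound 4 (0.14 log units; within the scatter) for compound 4, i.e. at most a small recovery toward the numbers of compounds 1 and 2, not clearly beyond the scatter in either direction. Compound 4 is estimated at 1 nM, with a range from 0.3 nM to 4 nM.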

Compound 4, half-maximal inhibitory concentration: 1.09 nM
The estimate for compound 4 lay 1.1-fold (0.04 log units) below the measured number, and the stated range covers the measured number.
By their numbers in this assay, from the lowest: compounds 1 and 2 (each within the scatter of the next); then compounds 4 and 3 (each within the scatter of the next).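

In this assay, an aromatic ring on this saturated chain carbon bound to the ring amine nitrogen cannot be told apart from tert-butyl (a 1.3-fold lower number from compound 3 to compound 4 (0.10 log units; within the scatter)), so the change from a branched chain to phenyl brings no readable recovery. The modest gap to the compounds with the smaller groups persists with phenyl, both against ethyl (a 2.1-fold higher number from compound 2 to compound 4 (0.33 log units; beyond the scatter)) and against hydrogen (a 2.6-fold higher number from compound 1 to compound 4 (0.41 log units; beyond the scatter)), so among these four compounds phenyl and tert-butyl stand together, apart from hydrogen and ethyl. No measured evidence bears on why these groups read as they do.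

Every group shown at this place is hydrogen or carbon only, which leaves open how a chain ending in an amine, a hydroxyl or a carboxylic acid would read here. Also open, going by these compounds, is whether a pyridine ring, with nitrogen in the aromatic ring, or a phenyl ring bearing fluorine or methoxy would stay with phenyl and tert-butyl or move toward the numbers of hydrogen and ethyl.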